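This account rests on a few compounds, and the source may have more. Where it says the series, first, only, none or still open, it means among the compounds named here.

In an ADME assay on BHK cells (Mesocricetus auratus) for cytotoxicity, read by MTT assay, with a stated time of 96 h (on this read-out higher numbers stand for lower toxicity in this test and lower numbers for higher toxicity in this test), compound 1 `COc1cccc(NC(=S)Nc2cccc(C(F)(F)F)c2)c1` gives 12000 nM. As far as these compounds go, compound 2 `CCNC(=S)Nc1cccc(C(F)(F)F)c1` gives > 100000 nM, which is a limit of the assay and not a number, so its true position is unknown. The change to compound 3 `FC(F)(F)c1cccc(NC(=S)Nc2cccc(Br)c2)c1` puts 3-bromophenyl in place of ethyl on an amide-type nitrogen. For the measured compounds named here, no measured pair of compounds differs in just one place, so the size of this change has no direct precedent. The nearest guide is compound 1, which also has an aromatic ring on that nitrogen and gives 12000 nM. The step of an at least 11-fold lower number from compound 2 to compound 3 (1.04 log units; beyond the scatter) is therefore expected to lower the number beyond the usual scatter, which would mean higher toxicity in this assay. For compound 3 the estimated value is 9000 nM, with an expected range from 2500 nM to 30000 nM.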

Compound 3, half-maximal cytotoxic concentration: 10000 nM
The estimate for compound 3 lay 1.1-fold (0.05 log units) below the measured number, within the range that was stated.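

In this assay, for the compounds shown here, 3-bromophenyl in place of ethyl on an amide-type nitrogen brings an at least 10-fold lower number from compound 2 to compound 3 (1.00 log units; beyond the scatter), the first measured single change at this nitrogen, and it points to higher toxicity in this test with the aromatic group there. As far as these compounds go, the true size of this step stays unknown, since compound 2 gives only a limit and not a number: the limit of > 100000 nM in this assay, at which 1 of the 3 values shown sits. By contrast, bromo in place of methoxy on an aromatic carbon brings a 1.2-fold lower number from compound 1 to compound 3 (0.08 log units; within the scatter), so this swap on the ring shows no real difference in this test.

From the compounds shown here alone, whether a longer chain such as butyl on that nitrogen would behave like ethyl or like the aromatic groups remains open. So does the effect of an amine or a carboxylic acid in place of the bromo.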